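The source may report more compounds than this note shows. Statements on the series, on what has been measured and on what is new or still open speak of the compounds shown alone.

Of the compounds shown here, two of a shared core have been tested. Compound 1 `CC(=O)O[C@@H]1C[C@@H](OC(C)=O)C(C)(C)[C@H](O)[C@H]2O[C@@]3(C[C@H](C)[C@H](OC(=O)c4ccccc4)[C@@H]3/C=C/1C)[C@@H](OC(C)=O)[C@H]2C` was tested in a functional assay on HeLa cells (Homo sapiens) for cytotoxicity, read by MTT assay (on this read-out lower numbers stand for stronger inhibition and higher numbers for weaker inhibition), and gave > 10000 nM, which is a limit of the assay rather than a number. Compound 2 `CC(=O)O[C@H]1[C@@H](C)/C=C/C(C)(C)[C@H](O)C[C@@H](O)/C(C)=C/[C@H]2[C@@H](OC(=O)c3ccccc3)[C@@H](C)C[C@@]21O` gave > 10000 nM in this assay, again a limit. Compound 2 therefore stands at the edge of what this assay can report, and both values shown sit there together: the limit of > 10000 nM in this assay, at which 2 of the 2 values shown sit.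

Compound 3 `CC(=O)O[C@@H]1C[C@@H](O)C(C)(C)/C=C/[C@H](C)[C@H](OC(C)=O)[C@@]2(O)C[C@H](C)[C@H](OC(=O)c3ccccc3)[C@@H]2/C=C/1C` is not yet measured. It differs from compound 2 in one place: acetyl in place of hydrogen on an oxygen on a saturated carbon. The change is small, an acetyl group on an oxygen that in compound 2 carries only a hydrogen.

Since compound 2 gives only a limit because of the limit of > 10000 nM in this assay, at which 2 of the 2 values shown sit, the step that the limit leaves unreadable from compound 2 to compound 3 is expected to be none beyond the scatter, with compound 3 most likely also at the limit. The estimate for compound 3 in this assay is 15000 nM, with a range from 4000 nM to 60000 nM.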

Compound 3, half-maximal inhibitory concentration: > 10000 nM
Compound 3: a limit, no number (the forecaster's own chance of this, stated with the estimate: 75%); the middle value does not contradict the limit.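

Within the data shown here, compound 2 and compound 3 both sit at a limit of the assay, not at a number, so no step between them can be read: the limit of > 10000 nM in this assay, at which 3 of the 3 values shown sit. The compounds shown leave open what changing hydroxy to acetoxy does to a compound that gives a readable number in this assay.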